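The compounds below may be only part of what the source reports. "The series", "measured", "known", "first", "only" and "open" are said of these compounds alone.

Of the compounds shown here, three have been tested in an ADME assay on H1-HeLa cells (Homo sapiens) for cytotoxicity, read by MTT assay, with a stated time of 3 days; a lower number here means that less compound is tolerated, a higher number that more compound is tolerated. Compound 1 `CCNC(=O)c1sc2cc(Oc3ccnc(C(=O)NC)c3)ccc2c1C` gives only a limit there, > 100000 nM. Compound 2 `CNC(=O)c1cc(Oc2ccc3cc(C(=O)OC(C)C)n(C)c3c2)ccn1` gives 10300 nM and compound 3 `CNC(=O)c1cc(Oc2ccc3c(C)c(C(=O)OC(C)C)[nH]c3c2)ccn1` gives 14600 nM. These two numbers lie within the usual scatter of each other, so compound 3 stands alongside compound 2, and no order can be drawn between them.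

Compound 4 `CNC(=O)c1cc(Oc2ccc3c(C)c(C(=O)OC(C)C)n(C)c3c2)ccn1` has not yet been measured. It differs from compound 3 in one place: methyl in place of hydrogen on an aromatic nitrogen. This is methyl in place of hydrogen on an aromatic nitrogen, next to the ring atom that bears an isopropoxycarbonyl group.

Among the measured compounds shown here, no measured pair isolates this change. The nearest guide is compound 2, which also carries a methyl on an aromatic nitrogen and gives 10300 nM, a number within the scatter of compound 3. On that basis, the expected step of a 1.2-fold lower number from compound 3 to compound 4 (0.09 log units; within the scatter) is estimated to stay within the scatter of this assay, with no clear direction. For compound 4 the expected value is 12000 nM, with an estimated range from 5000 nM to 32000 nM.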

Compound 4, half-maximal cytotoxic concentration: 11200 nM
The estimate for compound 4 lay 1.1-fold (0.03 log units) above the measured number; the range from low to high includes it.
By their numbers in this assay, from the lowest: compounds 2, 4 and 3 (each within the scatter of the next). At a limit, above all of these: compound 1.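

In this assay, methyl in place of hydrogen on an aromatic nitrogen now has a direct reading, a 1.3-fold lower number from compound 3 to compound 4 (0.12 log units; within the scatter), so at this nitrogen, next to the ring atom that bears an isopropoxycarbonyl group, the change stays within the scatter when the ring atom two ring bonds away bears a methyl group. The second pair reads a different place: methyl in place of hydrogen on an aromatic carbon gives a 1.1-fold higher number from compound 2 to compound 4 (0.04 log units; within the scatter), which also stays within the scatter, here with the aromatic nitrogen already carrying its methyl. Taken together, the two steps show that neither single methyl separates compound 4 from its neighbour in this assay, and nothing measured here speaks to a cause for either step.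

As far as these compounds go, both steps concern only a methyl group, so it remains open whether a longer chain on the aromatic nitrogen, such as propyl, would also stay within the scatter of compound 4. From the compounds shown here alone, it is equally open how this assay would read with a carboxylic acid in place of the isopropoxycarbonyl group.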